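Chloro in Place of Fluoro: Compound 2 to Compound 3

This account rests on a few compounds, and the source may have more. Where it says the series, first, only, none or still open, it means among the compounds named here.

Of the compounds shown here, two have been measured in an ADME assay on Vero cells (Chlorocebus sabaeus) for cytotoxicity, read by MTT assay, with a stated time of 72 h; on this read-out higher numbers stand for lower toxicity in this test and lower numbers for higher toxicity in this test. Compound 1 `CC/C(=C\c1ccc(Cl)cc1)C(=O)/C=C/c1ccc(Cl)cc1` gives 28300 nM in this assay. Compound 2 `COc1ccc(/C=C(\C)C(=O)/C=C/c2ccccc2F)cc1` gives 81200 nM in this assay, the higher of the two numbers, and the gap between compound 2 and compound 1 lies beyond the usual scatter. Compound 3 `COc1ccc(/C=C(\C)C(=O)/C=C/c2ccccc2Cl)cc1` has not yet been measured. It differs from compound 2 in one place: chloro in place of fluoro on an aromatic carbon. Among the compounds with values here, with only two measured compounds and no single-point comparison between them, there is no direct precedent for this exchange. The change is small, and the step from compound 2 to compound 3 is expected to be modest, most likely none beyond the scatter, with a slight lean toward a lower number, as a 1.4-fold lower number from compound 2 to compound 3 (0.13 log units; within the scatter). Compound 3 is accordingly expected to give about 60000 nM in this assay, within a range from 25000 nM to 150000 nM.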

Compound 3, half-maximal cytotoxic concentration: 74300 nM
Compound 3: middle estimate off by 1.2-fold (0.09 log units), on the low side, and the stated range covers the measured number.
By their numbers in this assay, from the lowest: compound 1; then compounds 3 and 2 (each within the scatter of the next).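

In this assay, within the data shown here, the exchange of 2-fluorophenyl to 2-chlorophenyl gives a 1.1-fold lower number from compound 2 to compound 3 (0.04 log units; within the scatter), and this is the only comparison here between compounds that differ in one place. At this position, on an aromatic carbon ortho to a large group, the read-out does not separate fluoro from chloro, so this exchange of one halogen for another leaves the number within the scatter. Nothing measured here bears on why the two compounds read alike. Going by these compounds, whether an amine or a carboxylic acid on this same aromatic carbon would also leave the number within the scatter remains open. So does the question of whether the exchange of fluoro for chloro would read the same way on the other carbons of this ring.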